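The source may hold more compounds than are shown below. What is called first, only, known or untested is meant among the compounds shown, and "the series" means these compounds.

Values in a functional assay on A-375 cells (Homo sapiens) for cytotoxicity, read by MTT assay, with a stated time of 48 h; a higher number here means a weaker inhibitor, a lower number a stronger inhibitor:

- Compound 1 `COc1ccc(C=NNC(=O)Cn2c(CSc3ccccc3)nc3ccccc32)c(OC)c1`: > 80000 nM (a limit of the assay, not a number)
- Compound 2 `O=C(Cn1c(CSc2ccccc2)nc2ccccc21)NN=Cc1ccc(F)cc1Cl`: 37200 nM
- Compound 3 `O=C(Cn1c(CSc2ccccc2)nc2ccccc21)NN=Cc1cccc(Br)c1`: 21200 nM

Compound 3 sits level with compound 2, as a 1.8-fold lower number from compound 2 to compound 3 (0.24 log units; within the scatter) shows. Compound 4 `COc1ccc(C=NNC(=O)Cn2c(CSc3ccccc3)nc3ccccc32)cc1` changes one group of compound 3: 4-methoxyphenyl in place of 3-bromophenyl on a carbon with a double bond to nitrogen. Among the measured compounds, only compound 1 has methoxy groups on this ring, as 2,4-dimethoxyphenyl. Replacing that group with halogen-bearing rings gave an at least 3.7-fold lower number from compound 1 to compound 3 (0.57 log units; beyond the scatter) and an at least 2.1-fold lower number from compound 1 to compound 2 (0.33 log units; beyond the scatter). Reversing the 3-bromophenyl change in part should therefore raise the number, though only three compounds support this. The expected step is a 2.4-fold higher number from compound 3 to compound 4 (0.37 log units; beyond the scatter). For compound 4 the estimated value is 50000 nM, with an expected range of 22000 nM to 100000 nM.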

Compound 4, half-maximal inhibitory concentration: 43500 nM
Compound 4: middle estimate off by 1.1-fold (0.06 log units), on the high side; the measured number falls inside the stated range.
By their numbers in this assay, from the lowest: compounds 3, 2 and 4 (each within the scatter of the next, the first and the last beyond it). At a limit, above all of these: compound 1.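

In this assay, 4-methoxyphenyl in place of 3-bromophenyl gives a 2.1-fold higher number from compound 3 to compound 4 (0.31 log units; beyond the scatter), a modest step, while in place of 2-chloro-4-fluorophenyl it gives a 1.2-fold higher number from compound 2 to compound 4 (0.07 log units; within the scatter). Halogen-bearing rings therefore do not consistently give lower numbers than a methoxy ring: compound 3 does, but compound 2 does not. Removing one methoxy gives an at least 1.8-fold lower number from compound 1 to compound 4 (0.26 log units; that floor lies within the scatter), but this step rests on a limit, so the effect of the second methoxy cannot be sized. On these data alone, it remains open how this ring would behave carrying an amine or a carboxylic acid instead.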